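The source may report more compounds than this note shows. Statements on the series, on what has been measured and on what is new or still open speak of the compounds shown alone.

Of the compounds shown here, three built on one shared core have been tested in a functional assay on MDA-MB-231 cells (Homo sapiens) for cytotoxicity, read by MTT assay, with a stated time of 48 h; a higher number here means a weaker inhibitor, a lower number a stronger inhibitor. Compound 1 `COc1ccc(-c2nc(-c3c[nH]c4ccccc34)co2)cc1OC` gives 103000 nM in this assay. Compound 2 `Fc1ccc(-c2nc(-c3c[nH]c4ccccc34)co2)cc1` gives 90400 nM in this assay, and compound 3 `C(=C/c1nc(-c2c[nH]c3ccccc23)co1)\c1ccccc1` gives 103000 nM in this assay. Compound 2 has the lowest of the three numbers, yet its gaps to compound 1 and to compound 3 both lie within the usual scatter of repeated measurements, so the three values cannot be told apart.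

Compound 4 `C=Cc1nc(-c2c[nH]c3ccccc23)co1` has not yet been measured in this assay. It differs from compound 2 in one place: vinyl in place of 4-fluorophenyl on an aromatic carbon. Within the data shown here, no step between two measured compounds that differ in a single place is available. What can be said is that compound 1, compound 2 and compound 3 carry different groups at this same place and give numbers within scatter of one another, so the expectation for compound 4 is a step of no more than the scatter, if anything toward a higher number. For compound 4 the estimated value in this assay is 120000 nM, with a range from 50000 nM to 300000 nM. The expected step of a 1.3-fold higher number from compound 2 to compound 4 (0.12 log units; within the scatter) is accordingly small.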

Compound 4, half-maximal inhibitory concentration: 103000 nM
Estimate against measurement, compound 4: 1.2-fold (0.07 log units) above, within the range that was stated.
By their numbers in this assay, from the lowest: compounds 2, 1, 3 and 4 (each within the scatter of the next).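

In this assay, among these compounds, the step of a 1.1-fold higher number from compound 2 to compound 4 (0.06 log units; within the scatter) is the first comparison of two measured compounds that differ in one place, here on an aromatic carbon of the five-membered ring. Compound 2 carries 4-fluorophenyl, a six-membered aromatic ring, whereas compound 4 carries vinyl, which has no ring and fewer heavy atoms, and the two values cannot be told apart. An aromatic ring at this place is therefore not needed for the number seen with compound 2.

Still open, from the compounds shown here alone, is whether any group at this place can move the number beyond the scatter, as an amine, a carboxylic acid or a longer chain in place of vinyl might or might not do. Nothing available offers an explanation for this result.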